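The source may hold more compounds than are shown below. What is called first, only, known or untested is meant among the compounds shown, and "the series" means these compounds.

The compounds share one core, seen in compound 3 `O=C(CN1CCCC1)Nc1ccc(-c2nc3ccccc3[nH]2)cc1`, and are followed here in an ADME assay on BHK cells (Mesocricetus auratus) for cytotoxicity, read by MTT assay, with a stated time of 96 h; a lower number here means that less compound is tolerated, a higher number that more compound is tolerated. Compound 1 `CC(=O)Nc1ccc(-c2nc3cc([N+](=O)[O-])ccc3[nH]2)cc1` is reported in this assay only as a limit, > 100000 nM. Compound 2 `CCN(CC)CC(=O)Nc1ccc(-c2nc3cc(C(F)(F)F)ccc3n2C)cc1` gives 16000 nM in this assay. Compound 3 gives 55000 nM, the highest of the two numbers shown, with compound 2 lower by a margin that lies beyond the usual scatter. Compound 4 `CC(=O)Nc1ccc(-c2nc3ccccc3[nH]2)cc1` has not yet been measured in this assay. It differs from compound 3 in one place: hydrogen in place of pyrrolidin-1-yl on a saturated chain carbon bound to a carbonyl carbon. No step between two measured compounds covers this particular change, so the expectation rests on what the shown values allow. The step from compound 3 to compound 4 is expected to be upward and modest, a 1.5-fold higher number from compound 3 to compound 4 (0.16 log units; within the scatter), a guess that rests on compound 1 with its acetyl standing at the limit of > 100000 nM in this assay, at which 1 of the 3 values shown sits. Compound 4 is therefore estimated at 80000 nM in this assay, within a range from 35000 nM to 200000 nM, with a fair chance that only a limit is reported.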

Compound 4, half-maximal cytotoxic concentration: > 100000 nM
Compound 4 ended at the assay's limit; the forecaster's own chance of this, stated with the estimate: 40%; at least 1.2-fold (0.09 log units) between middle value and limit.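

In this assay, the replacement of pyrrolidin-1-yl by hydrogen on a saturated chain carbon bound to a carbonyl carbon can now be read on its own, as an at least 1.8-fold higher number from compound 3 to compound 4 (0.25 log units; that floor lies within the scatter). The earlier compounds shown here offered no single-place step at this position, and this one gives only a floor for the change, not its full size. The step that links the nitro-bearing compound 1 to compound 4 cannot be read, and the top of the range now holds a second compound: the limit of > 100000 nM in this assay, at which 2 of the 4 values shown sit.

On these data alone, how far the true value of compound 4 lies from its limit remains open, so the full size of the change remains unknown. Also open, as far as these compounds go, is where a dimethylamino group, a carboxylic acid or a longer chain in place of pyrrolidin-1-yl would fall in this assay.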